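Series notes: compound 3 to compound 4, cytotoxicity

The source may hold more compounds than are shown below. What is called first, only, known or untested is meant among the compounds shown, and "the series" means these compounds.

Measured compounds:
compound 1 `C=C[C@@](C)(/C=C/c1ccc(O)cc1)CCC(=O)C(=C)C` — in a functional assay on K562 cells (Homo sapiens) for cytotoxicity, read by MTT assay, with a stated time of 48 h (on this read-out lower numbers stand for stronger inhibition and higher numbers for weaker inhibition), compound 1 gives > 10000 nM, a limit of the assay.
compound 2 `C=C[C@@](C)(/C=C/c1ccc(O)cc1)CC[C@@H](O)C(C)(C)O` — in this assay compound 2 gives > 10000 nM, a limit of the assay.
compound 3 `C=C[C@@](C)(/C=C/c1ccc(O)cc1)CCC1OC1(C)C` — in this assay compound 3 gives > 10000 nM, a limit of the assay.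

Compound 3 therefore stands only at a limit, as do the other two measured compounds; (the limit of > 10000 nM in this assay, at which 3 of the 3 values shown sit). None of the three compounds reaches a readable number in this assay. The step from compound 1 to compound 2 is a step that the two limits leave unreadable from compound 1 to compound 2; the step from compound 1 to compound 3 is a step that the two limits leave unreadable from compound 1 to compound 3; the step from compound 2 to compound 3 is a step that the two limits leave unreadable from compound 2 to compound 3. Among the compounds with values here, no measured step has a readable size.

Compound 4 `C=C[C@@](C)(/C=C/c1ccc(O)cc1)C/C=C/C(C)(C)O` differs from compound 3 by 3-hydroxy-3-methylbut-1-en-1-yl in place of (3,3-dimethyloxiran-2-yl)methyl on a saturated chain carbon, two bonds along the chain from two double-bonded chain carbons. Within the data shown here, no measured step bears directly on this change; the nearest, from compound 2 to compound 3, replaces one chain-end group by another of the same heavy-atom count and is itself unreadable. With every measured compound at the limit, no movement beyond the scatter can be expected in this assay in either direction.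

Compound 4 is expected to give 20000 nM, with a range from 8000 nM to 60000 nM. The step this estimate implies is a step that the limit leaves unreadable from compound 3 to compound 4, expected to stay within the scatter and most likely to be reported as a limit again.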

Compound 4, half-maximal inhibitory concentration: > 10000 nM
Compound 4: a limit, no number; the forecaster's own chance of this, stated with the estimate: 80%; the middle value is on the limit's open side.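

In this assay compound 4 gives > 10000 nM, a limit of the assay. No step from compound 1, compound 2 or compound 3 to compound 4 can be read, with all four compounds at the same limit: the limit of > 10000 nM in this assay, at which 4 of the 4 values shown sit.

The compounds shown leave open whether any of these groups on the shared core gives a readable number in this assay, and how they would rank.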